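Swapping a Cyclopropyl Triazole Substituent for a Sulfonamide

The source may report more compounds than this note shows. Statements on the series, on what has been measured and on what is new or still open speak of the compounds shown alone.

Going by the values given here, in a functional assay on MCF7 cells (Homo sapiens) for antiproliferative activity, read by MTT assay, with a stated time of 72 h (a lower number here means a stronger inhibitor, a higher number a weaker inhibitor), compound 2 `O=C1O[C@H]([C@@H](O)Cn2cc(C3CC3)nn2)C(OCc2ccccc2)=C1OCc1ccccc1` gives 25900 nM, the only actual number in this set. Compound 1 `COc1ccccc1-c1cn(C[C@H](O)[C@H]2OC(=O)C(OCc3ccccc3)=C2OCc2ccccc2)nn1` reaches a limit of the assay, > 100000 nM. Among the compounds with values here, the one measured step, an at least 3.8-fold lower number from compound 1 to compound 2 (0.58 log units; beyond the scatter), moved the number down when a smaller group took the place of a larger one. Compound 3 `Cc1ccc(S(=O)(=O)NCc2cn(C[C@H](O)[C@H]3OC(=O)C(OCc4ccccc4)=C3OCc3ccccc3)nn2)cc1` differs from compound 2 by (((4-methylphenyl)sulfonyl)amino)methyl in place of cyclopropyl on an aromatic carbon. This brings back a larger group, so the change is expected to run opposite to the measured step, giving a higher number and quite possibly only a limit again. Compound 3 is therefore estimated at 70000 nM, within 20000 nM to 300000 nM, a step of a 2.7-fold higher number from compound 2 to compound 3 (0.43 log units; beyond the scatter).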

Compound 3, half-maximal inhibitory concentration: 6400 nM
The estimate for compound 3 lay 11-fold (1.04 log units) above the measured number; measured number outside the range, below it.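

In this assay, a larger group on this aromatic carbon need not mean a higher number, and compound 3 goes against the earlier trend: (((4-methylphenyl)sulfonyl)amino)methyl in place of cyclopropyl gives a 4.0-fold lower number from compound 2 to compound 3 (0.61 log units; beyond the scatter). In place of 2-methoxyphenyl, the same group gives an at least 15-fold lower number from compound 1 to compound 3 (1.19 log units; beyond the scatter). Compound 1 sits at a limit, so that step is only a bound: the limit of > 100000 nM in this assay, at which 1 of the 3 values shown sits.

The compounds shown do not separate the roles of the sulfonamide, the methyl-bearing aromatic ring and the linking carbon. A simple aminomethyl group or a carboxylic acid on this carbon would help to tell them apart.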